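From ethyl to propyl on the shared core

A few compounds are considered here, and "the series" means these few. Any claim that something is new, unique, unknown or untested is made for them only; others in the source may bear on it.

Compound 1 `CCCCOC[C@H]1O[C@@H](CCC)[C@H](O)[C@@H](OCCCC)C1OCCCC`: > 50000 nM, a limit of the assay
Compound 2 `C[C@@H]1O[C@H](COCc2ccccc2)[C@@H](OCc2ccccc2)[C@H](OCc2ccccc2)C1=O`: > 50000 nM, a limit of the assay
Compound 3 `CC[C@@H]1O[C@H](COCc2ccccc2)[C@@H](OCc2ccccc2)[C@H](OCc2ccccc2)C1=O`: 4300 nM

For the measured compounds named here, in a functional assay on HOS cells (Homo sapiens) for antiproliferative activity, read by sulforhodamine B assay (a higher number here means a weaker inhibitor of growth, a lower number a stronger inhibitor of growth), compound 3 is the only one with a number, at 4300 nM. The other two values lie at the limit of > 50000 nM in this assay, at which 2 of the 3 values shown sit.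

Compound 4 `CCC[C@@H]1O[C@H](COCc2ccccc2)[C@@H](OCc2ccccc2)[C@H](OCc2ccccc2)C1=O` differs from compound 3 by methyl in place of hydrogen on a saturated chain carbon, two bonds along the chain from a saturated ring carbon. Going by the values given here, one measured step bears on this, the change of methyl to ethyl, an at least 11-fold lower number from compound 2 to compound 3 (1.06 log units; beyond the scatter). That large step is a single precedent, so a smaller step in the same direction in this assay is expected, a 2.2-fold lower number from compound 3 to compound 4 (0.33 log units; beyond the scatter). Compound 4 is estimated at 2000 nM, with an expected range of 500 nM to 8000 nM.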

Compound 4, concentration for 50% growth inhibition: > 50000 nM
Compound 4 gave a limit, no number; the forecaster's own chance of this, stated with the estimate: 5%; middle value at least 25-fold (1.39 log units) from the limit.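

In this assay, the change of ethyl to propyl reverses the earlier trend: an at least 11-fold higher number from compound 3 to compound 4 (1.06 log units; beyond the scatter), against an at least 11-fold lower number from compound 2 to compound 3 (1.06 log units; beyond the scatter). Among the methyl, ethyl and propyl compounds on this core, only the ethyl of compound 3 gives a number: the limit of > 50000 nM in this assay, at which 3 of the 4 values shown sit. The step between the two limits, from methyl to propyl, cannot be read.

The compounds shown leave open how far below the limit the methyl and propyl compounds lie. They also leave open whether an isopropyl group or an amine at the chain end would give a number at this position.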